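The source may hold more compounds than are shown below. What is called first, only, known or untested is meant among the compounds shown, and "the series" means these compounds.

In a functional assay on LOX IMVI cells (Homo sapiens) for cytotoxicity, read by MTT assay, with a stated time of 24 h (a higher number here means a weaker inhibitor, a lower number a stronger inhibitor), compound 3 `Cc1ccc(S(=O)(=O)NCCCNc2nccc(-c3[nH]c(-c4ccccc4)nc3-c3ccc(Cl)c(O)c3)n2)cc1` gives 6020 nM. That value lies within the usual scatter of compound 1 `COc1ccc(S(=O)(=O)NCCCNc2nccc(-c3[nH]c(-c4ccccc4)nc3-c3ccc(F)c(OC)c3)n2)cc1`, which gives 6130 nM, and is clearly lower than that of compound 2 `O=S(=O)(NCCCNc1nccc(-c2[nH]c(-c3ccccc3)nc2-c2ccc(Cl)c(O)c2)n1)c1cccc(F)c1`, which gives 33600 nM. Compound 4 `COc1ccc(S(=O)(=O)NCCCNc2nccc(-c3[nH]c(-c4ccccc4)nc3-c3ccc(Cl)c(O)c3)n2)cc1`, not yet measured, keeps all of compound 3 except one group: methoxy in place of methyl on an aromatic carbon, para to a large group (methoxy in place of methyl on an aromatic carbon). Cut one bond further out, a 4-methylphenyl on the sulfonyl sulfur becomes a 4-methoxyphenyl.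

Going by the values given here, only one measured step touches this same group, a 5.6-fold lower number from compound 2 to compound 3 (0.75 log units; beyond the scatter), where 4-methylphenyl took the place of 3-fluorophenyl. It lies beyond the scatter and is modest, so changes here can move the number, but it says nothing direct about methyl against methoxy. Among the compounds with values here, no measured pair makes exactly that swap. Compound 1, at 6130 nM, already carries the 4-methoxyphenyl, though it differs from compound 4 elsewhere in the molecule, and its value gives no sign of a large penalty for that group. A small change with no firm direction therefore seems most likely in this assay. The expected step is a 1.2-fold higher number from compound 3 to compound 4 (0.07 log units; within the scatter), which would probably stay within the scatter. For compound 4 the estimated value is 7000 nM, with an expected range of 3000 nM to 16000 nM.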

Compound 4, half-maximal inhibitory concentration: 36800 nM
The estimate for compound 4 lay 5.3-fold (0.72 log units) below the measured number, and the stated range ends below it.
By their numbers in this assay, from the lowest: compounds 3 and 1 (each within the scatter of the next); then compounds 2 and 4 (each within the scatter of the next).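

In this assay, the move from methyl to methoxy on an aromatic carbon, para to a large group, is a real change and not a small adjustment: a 6.1-fold higher number from compound 3 to compound 4 (0.79 log units; beyond the scatter). Replacing 3-fluorophenyl with 4-methoxyphenyl on the sulfonyl sulfur gives a 1.1-fold higher number from compound 2 to compound 4 (0.04 log units; within the scatter), so among the compounds carrying 4-chloro-3-hydroxyphenyl, the 4-methylphenyl of compound 3 stands apart from the other two sulfonyl groups. Changing the other aryl group gives a 6.0-fold higher number from compound 1 to compound 4 (0.78 log units; beyond the scatter), which shows that the value of compound 1 could not speak for the 4-methoxyphenyl group alone, since the same group sits at clearly different numbers in the two molecules. No measurement at hand explains these differences.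

The compounds shown leave open whether the lower number of compound 3 belongs to methyl specifically, which an ethyl, a chlorine or a bare hydrogen at the same place could test. They also leave open how 4-methylphenyl behaves alongside 4-fluoro-3-methoxyphenyl, the pairing that would show whether the two parts of the molecule act independently.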